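Oxamide thiazoles: effect of 2-chloro-6-fluorophenyl in vivo

This account rests on a few compounds, and the source may have more. Where it says the series, first, only, none or still open, it means among the compounds named here.

Compound 1 `CCOCCOC(=O)C(=O)Nc1nc(-c2c(-c3ccccc3)noc2C)cs1` is the ethoxyethyl ester; compound 2 `CCOCCOC(=O)C(=O)Nc1nc(-c2c(-c3c(F)cccc3Cl)noc2C)cs1` carries 2-chloro-6-fluorophenyl in place of phenyl on an aromatic carbon. In a functional assay on the whole organism with Rattus norvegicus as the target (a lower number here means that less compound is needed, a higher number that more compound is needed for the effect), compound 1 gives > 10 mg/kg, a limit of the assay. In this assay compound 2 gives > 10 mg/kg, also a limit. The step that the two limits leave unreadable from compound 1 to compound 2 rests on two limits; the relevant evidence is the limit of > 10 mg/kg in this assay, at which 2 of the 3 values shown sit.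

Compound 3 `O=C(O)C(=O)Nc1nc(-c2conc2-c2ccccc2)cs1` is the free acid on a core whose difference from the core of compound 1 is not broken down here. In this assay compound 3 gives > 100 mg/kg, a limit; this is the limit of > 100 mg/kg in this assay, at which 1 of the 3 values shown sits.

Compound 4 `O=C(O)C(=O)Nc1nc(-c2conc2-c2c(F)cccc2Cl)cs1` is to be measured and differs from compound 3 by 2-chloro-6-fluorophenyl in place of phenyl on an aromatic carbon; the place lines differ only in that the place in compound 1 is also two ring bonds from the ring atom that bears a methyl group, so this is the same kind of change. With compound 2 sitting at > 10 mg/kg and compound 3 at its limit, the expected step that the limit leaves unreadable from compound 3 to compound 4 is small. Compound 4 is estimated at 150 mg/kg, most likely again reported only as a limit.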

Compound 4, dose for half-maximal effect: 30 mg/kg
The estimate for compound 4 lay 5.0-fold (0.70 log units) above the measured number; measured number inside the range.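

On the free-acid core, 2-chloro-6-fluorophenyl in place of phenyl gives an at least 3.3-fold lower number from compound 3 to compound 4 (0.52 log units; beyond the scatter) in this assay, and the size is a lower bound only. On the core of compound 1, the same change cannot be read, with compound 1 and compound 2 both at the limit: the limit of > 10 mg/kg in this assay, at which 2 of the 4 values shown sit. The gain is therefore shown on one core only, and the data neither confirm nor contradict that it carries over to the other.

Open, on these data alone, is whether 2-chlorophenyl or 2-fluorophenyl alone would give a similar step on the free-acid core. Also open, as far as these compounds go, is how the free acid and the ethoxyethyl ester compare on a single core.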